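One chain removed from compound 1

The source may hold more compounds than are shown below. What is called first, only, known or untested is meant among the compounds shown, and "the series" means these compounds.

Measured so far in a functional assay on liver (Rattus norvegicus, strain Sprague-Dawley) for inhibition, with a stated time of 1 h; on this read-out lower numbers stand for stronger inhibition and higher numbers for weaker inhibition:
- compound 1 `COc1cc(C2Oc3cc(-c4oc5cc(OCC=C(C)C)cc(O)c5c(=O)c4O)ccc3OC2CO)ccc1OCC=C(C)C` with 28100 nM
- compound 2 `C=CCOc1cc(O)c2c(=O)c(O)c(-c3ccc4c(c3)OC(c3ccc(OCC=C)c(OC)c3)C(CO)O4)oc2c1` with 22600 nM
- compound 3 `COc1cc(C2Oc3cc(-c4oc5cc(O)cc(O)c5c(=O)c4O)ccc3OC2COC(=O)c2cccc(Cl)c2)ccc1O` with 16900 nM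

Compound 1 sits within the usual scatter of both compound 2 and compound 3, so these three values cannot be ranked.

Compound 4 `COc1cc(C2Oc3cc(-c4oc5cc(OCC=C(C)C)cc(O)c5c(=O)c4O)ccc3OC2CO)ccc1O` has not been measured yet. It comes from compound 1 by a single change, (hydrogen in place of 3-methylbut-2-en-1-yl on an oxygen on an aromatic ring), which puts hydrogen in place of 3-methylbut-2-en-1-yl on an oxygen on an aromatic ring. Put another way, (3-methylbut-2-en-1-yl)oxy becomes hydroxy.

For the measured compounds named here, no two measured compounds differ in just one place, so no measured step shows what a change like this does. The data offer only the closeness of the values, with compound 1 at 28100 nM and compound 3 at 16900 nM lying within the scatter of each other. On that basis, no step beyond the scatter is expected in this assay for this change.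

The expected move is a 1.4-fold lower number from compound 1 to compound 4 (0.15 log units; within the scatter) and would stay within the scatter. For compound 4 the estimated value is 20000 nM, with an expected range from 8000 nM to 50000 nM for the measurement to come.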

Compound 4, half-maximal inhibitory concentration: 23300 nM
Beside the measured number, compound 4's estimate is 1.2-fold (0.07 log units) below it, within the range that was stated.
By their numbers in this assay, from the lowest: compounds 3, 2, 4 and 1 (each within the scatter of the next).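

For the compounds shown here, this pair gives the first measured step for a change in one place. In this assay the swap of (3-methylbut-2-en-1-yl)oxy for hydroxy gives a 1.2-fold lower number from compound 1 to compound 4 (0.08 log units; within the scatter) and so shows no readable effect of removing this chain from the oxygen on the aromatic ring. Compound 4 still carries its other 3-methylbut-2-en-1-yl chain, and no measurement here offers an explanation for the size of this step.

As far as these compounds go, it remains open whether another group on this oxygen, such as a methyl, a longer chain or a chain ending in an amine or a carboxylic acid, would move the number beyond the scatter. From the compounds shown here alone, it also remains open whether the other 3-methylbut-2-en-1-yl chain could be replaced by hydrogen with as little effect.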